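Two chain stereocentres inverted: compound 3 to compound 4

This account rests on a few compounds, and the source may have more. Where it says the series, first, only, none or still open, it means among the compounds named here.

In a functional assay on cells (Platelet, Oryctolagus cuniculus) for inhibition, read by turbidimetry, with a stated time of 5 min (on this read-out higher numbers stand for weaker inhibition and lower numbers for stronger inhibition), compound 3 `CCCC[C@@H](OC(=O)CN1CCCC1)c1ccccc1C(=O)O[C@H]1CO[C@H]2[C@@H]1OC[C@H]2OC(=O)c1ccccc1[C@@H](CCCC)OC(=O)CN1CCCC1` gives 910000 nM, the highest number of the three measured. Compound 1 `CCCC[C@H](OC(=O)CN(C)C)c1ccccc1C(=O)O[C@H]1CO[C@H]2[C@@H]1OC[C@H]2OC(=O)c1ccccc1[C@H](CCCC)OC(=O)CN(C)C` gives 200000 nM and compound 2 `CCCC[C@H](OC(=O)CN1CCN(C)CC1)c1ccccc1C(=O)O[C@H]1CO[C@H]2[C@@H]1OC[C@H]2OC(=O)c1ccccc1[C@H](CCCC)OC(=O)CN1CCN(C)CC1` gives 50000 nM, both lower beyond the scatter. Compound 4 `CCCC[C@H](OC(=O)CN1CCCC1)c1ccccc1C(=O)O[C@H]1CO[C@H]2[C@@H]1OC[C@H]2OC(=O)c1ccccc1[C@H](CCCC)OC(=O)CN1CCCC1` is related to compound 3 as follows: the two compounds have the same atoms and bonds and differ only in configuration as drawn: 2 of 6 stereo elements differ; a stereocentre at a saturated chain carbon is drawn R in compound 3 and S in compound 4; a stereocentre at a saturated chain carbon is drawn R in compound 3 and S in compound 4. Among the measured compounds shown here, compound 1 and compound 2 are drawn with the configuration of compound 4 at these stereocentres, but they carry different amine groups, so no measured pair isolates this change. The expected step of a 5.4-fold lower number from compound 3 to compound 4 (0.73 log units; beyond the scatter) is toward a lower number in this assay, beyond the scatter, resting on compound 1 at 200000 nM. For compound 4 the estimated value is 170000 nM, with an expected range from 40000 nM to 600000 nM.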

Compound 4, half-maximal inhibitory concentration: 640000 nM
Compound 4: middle estimate off by 3.8-fold (0.58 log units), on the low side; measured number above the stated range.
By their numbers in this assay, from the lowest: compound 2; then compound 1; then compounds 4 and 3 (each within the scatter of the next).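

Among the compounds shown here, this is the first pair that isolates configuration at the two chain stereocentres, with no other change to read: the fact that compounds 3 and 4 differ only in the configuration as drawn. In this assay the inversion gives a 1.4-fold lower number from compound 3 to compound 4 (0.15 log units; within the scatter), so configuration at these two stereocentres does not separate the pair on this read-out.

Open, from the compounds shown here alone, is whether this holds with the amine groups of compound 1 and compound 2, or when only one stereocentre is inverted. Also open, going by these compounds, is how a carboxylic acid in place of the amine, or a longer chain, would read.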